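Swapping Cyclohexylamino for 4-Oxopiperidin-1-yl in Compound 1

A few compounds are considered here, and "the series" means these few. Any claim that something is new, unique, unknown or untested is made for them only; others in the source may bear on it.

Of the compounds shown here, three sharing one core have been tested in a functional assay on CHO-K1 cells for antagonist activity at transient receptor potential cation channel subfamily V member 1 (Homo sapiens), read by FLIPR; on this read-out lower numbers stand for stronger inhibition and higher numbers for weaker inhibition. Compound 1 `CC(C(=O)NCc1ccc(C(F)(F)F)nc1NC1CCCCC1)c1ccc(NS(C)(=O)=O)c(F)c1` gives 20.4 nM, the highest of the two numbers on record. Compound 3 `C[C@@H](C(=O)NCc1ccc(C(F)(F)F)nc1N1CCC(c2ccccc2)CC1)c1ccc(NS(C)(=O)=O)c(F)c1` gives 7.5 nM, a lower number that lies beyond the usual scatter, while compound 2 `CC(C(=O)NCc1ccc(C(F)(F)F)nc1NCc1cccnc1)c1ccc(NS(C)(=O)=O)c(F)c1` is reported as "not active" (no number reported). Compound 4 `CC(C(=O)NCc1ccc(C(F)(F)F)nc1N1CCC(=O)CC1)c1ccc(NS(C)(=O)=O)c(F)c1` has not yet been measured. It differs from compound 1 at a single place: 4-oxopiperidin-1-yl in place of cyclohexylamino on an aromatic carbon. Among the measured compounds shown here, no step between two measured compounds differing in one place is available, so the outcome rests on expectation alone. The step is expected to be a 3.9-fold higher number from compound 1 to compound 4 (0.59 log units; beyond the scatter), a weakening of moderate size beyond the scatter. The estimate for compound 4 is 80 nM, ranging from 20 nM to 400 nM.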

Compound 4, inhibition constant: 91 nM
Beside the measured number, compound 4's estimate is 1.1-fold (0.06 log units) below it; measured number inside the range.
By their numbers in this assay, from the lowest: compound 3; then compound 1; then compound 4.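

In this assay, the first step read at this position, on an aromatic carbon next to the ring nitrogen, is a 4.5-fold higher number from compound 1 to compound 4 (0.65 log units; beyond the scatter), so exchanging cyclohexylamino for 4-oxopiperidin-1-yl weakens inhibition without abolishing it. The change keeps the ring size and heavy-atom count but removes the hydrogen-bond donor and adds a carbonyl. Nothing at hand accounts for the step. As far as these compounds go, it remains open whether an unsubstituted piperidin-1-yl or a morpholin-4-yl would give a number nearer to that of compound 1 or of compound 4, which would help separate the loss of the amine hydrogen from the entry of the carbonyl.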